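The source may report more compounds than this note shows. Statements on the series, on what has been measured and on what is new or still open speak of the compounds shown alone.

Measured so far in a functional assay on HT-29 cells (Homo sapiens) for cytotoxicity, read by sulforhodamine B assay, with a stated time of 48 h; on this read-out higher numbers stand for weaker inhibition of growth and lower numbers for stronger inhibition of growth:

compound 1, `ClCc1cccc(Cn2cnc3c(Cl)ncnc32)c1`: > 100000 nM
compound 2, `ClCc1cccc(Cn2cnc3c(Cl)nc(Cl)nc32)c1`: > 100000 nM
compound 3, `ClCc1ccccc1Cn1cnc2ncnc(Cl)c21`: > 100000 nM

In this assay compound 1 gives > 100000 nM, which is a limit of the assay and not a number. Compound 2 likewise gives only a limit, > 100000 nM. Compound 3 also gives only a limit, > 100000 nM. The change from compound 1 to compound 2 is chloro in place of hydrogen on an aromatic carbon and its step is a step that the two limits leave unreadable from compound 1 to compound 2. The difference between the cores of compound 1 and compound 3 is not broken down here.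

Compound 4, `ClCc1ccccc1Cn1cnc2nc(Cl)nc(Cl)c21`, is not yet measured; it differs from compound 3 by chloro in place of hydrogen on an aromatic carbon, the same change with the same surroundings as from compound 1 to compound 2. For the measured compounds named here, the only evidence on this change is the limit of > 100000 nM in this assay, at which 3 of the 3 values shown sit, so no direction can be read from it.

Compound 4 is expected to give 150000 nM, most likely again as a limit, with a range of 50000 nM to 600000 nM. The expected step is a step that the limit leaves unreadable from compound 3 to compound 4, resting on compound 1 and compound 2 both sitting at the limit of > 100000 nM in this assay, at which 3 of the 3 values shown sit.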

Compound 4, concentration for total growth inhibition: > 100000 nM
Compound 4 was reported as a limit; the forecaster's own chance of this, stated with the estimate: 85%; the middle value lies beyond the limit too.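

No step from compound 3 to compound 4 can be read, as both stand only as limits in this assay: the limit of > 100000 nM in this assay, at which 4 of the 4 values shown sit.

The compounds shown leave open whether chloro in place of hydrogen on an aromatic carbon changes growth inhibition at all, in either direction.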